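The source may report more compounds than this note shows. Statements on the series, on what has been measured and on what is new or still open speak of the compounds shown alone.

Measured compounds in an ADME assay on L929 cells (Mus musculus) for cytotoxicity, read by resazurin assay, with a stated time of 48 h; a lower number here means that less compound is tolerated, a higher number that more compound is tolerated:
Compound 1 `O=c1c2cc([N+](=O)[O-])ccc2n(CCCBr)n1Cc1ccccc1` gives 25200 nM.
Compound 2 `COC(=O)CCn1c2ccc([N+](=O)[O-])cc2c(=O)n1Cc1ccccc1` gives > 256000 nM, a limit of the assay rather than a number.
Compound 3 `CN(C)C(=O)CCCn1c2ccc([N+](=O)[O-])cc2c(=O)n1Cc1ccccc1` gives > 256000 nM, likewise a limit.

Compound 2 stands at the limit of > 256000 nM in this assay, at which 2 of the 3 values shown sit, with no number of its own. Compound 4 `CCOCCCn1c2ccc([N+](=O)[O-])cc2c(=O)n1Cc1ccccc1` differs from compound 2 by ethoxymethyl in place of methoxycarbonyl on a saturated chain carbon, two bonds along the chain from an aromatic nitrogen. Among the compounds with values here, no measured step covers this exact exchange. The nearest information is an at least 10-fold higher number from compound 1 to compound 2 (1.00 log units; beyond the scatter) and an at least 10-fold higher number from compound 1 to compound 3 (1.00 log units; beyond the scatter), both reaching the limit, while a step that the two limits leave unreadable from compound 2 to compound 3. On that basis compound 4 is expected to sit near the limit again in this assay, giving an at least 1.4-fold lower number from compound 2 to compound 4 (0.15 log units; that floor lies within the scatter) as the expected step. Compound 4 is estimated at 180000 nM, within 50000 nM to 256000 nM.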

Compound 4, concentration lethal to 50% of the cells: 170000 nM
For compound 4 the middle estimate is 1.1-fold (0.02 log units) above the measured one; low and high end bracket the measured number.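

In this assay, the ethoxy chain of compound 4 gives a readable number rather than a limit, and replacing bromo with ethoxy gives a 6.7-fold higher number from compound 1 to compound 4 (0.83 log units; beyond the scatter). Going by these compounds, the exchanges of the ester and the amide for the ether read an at least 1.5-fold lower number from compound 2 to compound 4 (0.17 log units; that floor lies within the scatter) and an at least 1.5-fold lower number from compound 3 to compound 4 (0.17 log units; that floor lies within the scatter); these are floors only, so their true size stays unknown. Compound 2 and compound 3 are limits, not numbers: the limit of > 256000 nM in this assay, at which 2 of the 4 values shown sit.

The step between compound 2 and compound 3 cannot be read. On these data alone, how an amine, a carboxylic acid or a longer chain at this position would fare remains open.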